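This account rests on a few compounds, and the source may have more. Where it says the series, first, only, none or still open, it means among the compounds named here.

Compound 1, with the structure `Cc1cc(S(=O)(=O)/N=C(\N)N/N=C/C#Cc2ccccc2)c(SCc2ccccc2)cc1Cl`, is the starting point of this small set. In an ADME assay on microsomes from liver (Homo sapiens) for metabolic stability, read by LC-MS, using NADPH, tested at 5 uM (on this read-out lower numbers stand for a shorter-lived compound and higher numbers for a longer-lived compound), compound 1 gives 0.469 h. Compound 2, with the structure `C/C(C#Cc1ccccc1)=N\N/C(N)=N/S(=O)(=O)c1cc(C)c(Cl)cc1SCc1ccccc1`, differs from it by a group of 11 heavy atoms (10 carbon, 1 nitrogen; one six-membered aromatic ring of carbon only) in place of a group of 10 heavy atoms (9 carbon, 1 nitrogen; one six-membered aromatic ring of carbon only), on an amine nitrogen, and in this assay compound 2 gives 0.466 h; the change is a 1.0-fold lower number from compound 1 to compound 2 (0.00 log units; within the scatter). Compound 3, with the structure `Cc1cc(S(=O)(=O)/N=C(\N)N/N=C/C#Cc2ccccc2)c(SCc2ccccc2C(F)(F)F)cc1Cl`, differs from compound 1 by trifluoromethyl in place of hydrogen on an aromatic carbon, and in this assay compound 3 gives 0.653 h; the change is a 1.4-fold higher number from compound 1 to compound 3 (0.14 log units; within the scatter). All three numbers lie close together, so none of the compounds can be told apart from the others on this read-out.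

Compound 4, with the structure `C/C(C#Cc1ccccc1)=N\N/C(N)=N/S(=O)(=O)c1cc(C)c(Cl)cc1SCc1ccccc1C(F)(F)F`, has not yet been measured. It differs from compound 3 by a group of 11 heavy atoms (10 carbon, 1 nitrogen; one six-membered aromatic ring of carbon only) in place of a group of 10 heavy atoms (9 carbon, 1 nitrogen; one six-membered aromatic ring of carbon only), on an amine nitrogen, the same change that separates compound 1 from compound 2, made on a core that differs from the core of compound 1 by trifluoromethyl in place of hydrogen on an aromatic carbon. Because that earlier change was a 1.0-fold lower number from compound 1 to compound 2 (0.00 log units; within the scatter), the step from compound 3 to compound 4 is expected to be small as well, about a 1.0-fold lower number from compound 3 to compound 4 (0.00 log units; within the scatter). Compound 4 is therefore estimated to give about 0.65 h, likely between 0.4 h and 1.05 h.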

Compound 4, half-life: 0.107 h
For compound 4 the middle estimate is 6.1-fold (0.78 log units) above the measured one, and the stated range ends above it.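

Carrying this change from one core to another does not work in this series. In this assay, swapping the group of 10 heavy atoms for the group of 11 heavy atoms on the amine nitrogen gives a 6.1-fold lower number from compound 3 to compound 4 (0.79 log units; beyond the scatter), so the near-zero step seen on the core of compound 1 does not predict the step on the core of compound 3: the same change on two cores in this assay, a 1.0-fold lower number (0.00 log units; within the scatter) from compound 1 to compound 2 and a 6.1-fold lower number (0.79 log units; beyond the scatter) from compound 3 to compound 4, 6.1-fold (0.78 log units) apart, beyond the scatter of two such steps

Read the other way, trifluoromethyl in place of hydrogen on the aromatic carbon gives a 4.4-fold lower number from compound 2 to compound 4 (0.64 log units; beyond the scatter), which does not match its step on the core of compound 1: the same change on two cores in this assay, a 1.4-fold higher number (0.14 log units; within the scatter) from compound 1 to compound 3 and a 4.4-fold lower number (0.64 log units; beyond the scatter) from compound 2 to compound 4, 6.1-fold (0.78 log units) apart, beyond the scatter of two such steps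

Together these steps show that the two changes do not act independently in compound 4, but they rest on one set of four compounds and do not show why the half-life falls.

As far as these compounds go, whether a fluorine or a methoxy group in place of trifluoromethyl would bring the same drop stays open. So does whether a longer chain in place of the extra carbon of the group of 11 heavy atoms would do so.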